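The source may hold more compounds than are shown below. What is called first, only, known or untested is meant among the compounds shown, and "the series" means these compounds.

Working notes on the series. Among the measured compounds shown here, compound 3 `COc1ccccc1-c1nnc(-c2ccc(C(=O)N/N=C/c3cccc(F)c3)cc2)o1` gives 353000 nM in an ADME assay on THP-1 cells (Homo sapiens) for cytotoxicity (a higher number here means a weaker inhibitor, a lower number a stronger inhibitor), the highest of the three numbers measured so far. Compound 1 `COc1ccccc1-c1nnc(-c2ccc(C(=O)N/N=C/c3cc(O)ccc3O)cc2)o1` gives 100000 nM in this assay, and compound 2 `COc1ccccc1-c1nnc(-c2ccc(C(=O)N/N=C/c3ccc([N+](=O)[O-])cc3)cc2)o1` gives 203000 nM. The step of a 3.5-fold higher number from compound 1 to compound 3 (0.55 log units; beyond the scatter) lies beyond the scatter, whereas a 1.7-fold higher number from compound 2 to compound 3 (0.24 log units; within the scatter) does not, so compound 3 and compound 2 cannot be separated on these numbers.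

Compound 4 `COc1ccccc1-c1nnc(-c2ccc(C(=O)N/N=C/c3ccccc3F)cc2)o1` is the next member; the change from compound 3 is 2-fluorophenyl in place of 3-fluorophenyl on a carbon with a double bond to nitrogen. For the measured compounds named here, no measured step moves a fluorine from one position of the ring to another: a 2.0-fold higher number from compound 1 to compound 2 (0.31 log units; beyond the scatter) and a 3.5-fold higher number from compound 1 to compound 3 (0.55 log units; beyond the scatter) each replace the 2,5-dihydroxyphenyl, and a 1.7-fold higher number from compound 2 to compound 3 (0.24 log units; within the scatter) exchanges the 4-nitrophenyl for the 3-fluorophenyl. The closest guide is therefore a 1.7-fold higher number from compound 2 to compound 3 (0.24 log units; within the scatter), which stays within the scatter, and the two dihydroxyphenyl steps are modest in size. For compound 4 in this assay the expectation is accordingly a step of a 1.0-fold lower number from compound 3 to compound 4 (0.00 log units; within the scatter), no larger than the scatter. Compound 4 is estimated at 350000 nM, with a range of 150000 nM to 800000 nM.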

Compound 4, half-maximal inhibitory concentration: 313000 nM
The estimate for compound 4 lay 1.1-fold (0.05 log units) above the measured number; the range from low to high includes it.
By their numbers in this assay, from the lowest: compound 1; then compounds 2, 4 and 3 (each within the scatter of the next).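

Working notes, continued. In this assay, among the compounds shown here, a 1.1-fold lower number from compound 3 to compound 4 (0.05 log units; within the scatter) gives the first direct comparison of two fluorine placements on this ring, and the two fluorophenyl compounds cannot be separated on these numbers. With a 1.5-fold higher number from compound 2 to compound 4 (0.19 log units; within the scatter), the 2-fluorophenyl also cannot be separated from the 4-nitrophenyl, whereas a 3.1-fold higher number from compound 1 to compound 4 (0.50 log units; beyond the scatter) sets it apart from the 2,5-dihydroxyphenyl, which remains the only group at this place whose compound stands beyond the scatter from all the others shown. No measurement is available to account for these results.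

The compounds shown leave open whether the separation of compound 1 comes from the two hydroxyl groups together or from only one of them, as no compound here carries a single hydroxyl on the ring. They also leave open how an unsubstituted phenyl, or a phenyl bearing an amine or a carboxylic acid, would read on a carbon with a double bond to nitrogen, and whether any group at this place can give a step larger than the modest ones seen so far.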